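A few compounds are considered here, and "the series" means these few. Any claim that something is new, unique, unknown or untested is made for them only; others in the source may bear on it.

Measured compounds: compound 1 `Cc1cc(C(=O)NN2CCOCC2)nn1Cc1cc(Cl)ccc1OCC(C)C` gives 251 nM in an assay on CHO-K1 cells for displacement of a labelled ligand from prostaglandin E2 receptor EP1 subtype (Homo sapiens); a higher number here means a weaker inhibitor, a lower number a stronger inhibitor; compound 2 `Cc1cc(NC(=O)C2CCOCC2)nn1Cc1cc(Cl)ccc1OCc1ccccc1` gives 63.1 nM; compound 3 `Cc1cc(NC(=O)O[C@H]2CCOC2)nn1Cc1cc(Cl)ccc1OCc1ccccc1` gives 79.4 nM.

Compound 1 shows the highest number of the three. Compound 4 `Cc1cc(NC(=O)OC(C)C)nn1Cc1cc(Cl)ccc1OCC(C)C` differs from compound 1 by (isopropoxycarbonyl)amino in place of (morpholin-4-yl)carbamoyl on an aromatic carbon. Going by the values given here, no measured step covers this exact change. Among the compounds with values here, the one step available, a 1.3-fold higher number from compound 2 to compound 3 (0.10 log units; within the scatter), shows that changing the group on the carbonyl carbon hardly matters when the nitrogen stays attached to the ring. Compounds 2 and 3, both carrying such a nitrogen-linked carbonyl group, give lower numbers than compound 1, although they also differ from compound 1 in another part of the molecule. Compound 4 is therefore expected to give a somewhat lower number, a step of a 2.3-fold lower number from compound 1 to compound 4 (0.36 log units; beyond the scatter). The estimate for compound 4 is 110 nM, between 45 nM and 260 nM.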

Compound 4, half-maximal inhibitory concentration: 50.1 nM
Compound 4: middle estimate off by 2.2-fold (0.34 log units), on the high side; the measured number falls inside the stated range.
By their numbers in this assay, from the lowest: compounds 4, 2 and 3 (each within the scatter of the next); then compound 1.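

On the core of compound 1, placing (isopropoxycarbonyl)amino in place of (morpholin-4-yl)carbamoyl on the aromatic carbon gives a 5.0-fold lower number from compound 1 to compound 4 (0.70 log units; beyond the scatter) in this assay. This is the first change shown at this position with the rest of the molecule held fixed, and it shows that the number here depends on the group at this position and that the lower number needs no ring in that group. No measurement explains this step. From the compounds shown here alone, it remains open which part of the new group accounts for the step, and whether a butoxycarbonylamino chain or a carboxylic acid on this aromatic carbon would keep the lower number.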